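Chlorophenyl change on the sulfonamide nitrogen: working notes

The compounds below may be only part of what the source reports. "The series", "measured", "known", "first", "only" and "open" are said of these compounds alone.

Values in a functional assay on MCF7 cells (Homo sapiens) for antiproliferative activity, read by MTT assay, with a stated time of 72 h (on this read-out higher numbers stand for weaker inhibition and lower numbers for stronger inhibition), so far
- compound 1 `CCN(c1ccc(OC)cc1)S(=O)(=O)C1CC2OC1C(c1ccc(NC(=O)CCCCCCC(=O)O)cc1)=C2c1ccc(O)cc1` gives 20300 nM
- compound 2 `CCN(c1ccccc1Cl)S(=O)(=O)C1CC2OC1C(c1ccc(NC(=O)CCCCCCC(=O)O)cc1)=C2c1ccc(O)cc1` gives 33300 nM

Among the compounds with values here, compound 2 at 33300 nM has only one measured neighbour, and the gap to it lies within the scatter, so no ranking can be drawn. Compound 3 `CCN(c1ccc(Cl)cc1)S(=O)(=O)C1CC2OC1C(c1ccc(NC(=O)CCCCCCC(=O)O)cc1)=C2c1ccc(O)cc1` carries 4-chlorophenyl in place of 2-chlorophenyl on a sulfonamide nitrogen. Within the data shown here, the only measured step bearing on this (a 1.6-fold higher number from compound 1 to compound 2 (0.21 log units; within the scatter)) is a different exchange at the same place, and it stayed within the scatter. Among the measured compounds shown here, no measurement yet isolates the change from 2-chlorophenyl to 4-chlorophenyl, so no firm direction can be assigned. The expected result in this assay is no change beyond the scatter (a 1.3-fold lower number from compound 2 to compound 3 (0.11 log units; within the scatter)). For compound 3 the estimated value is 26000 nM (expected range 12000 nM to 52000 nM).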

Compound 3, half-maximal inhibitory concentration: 22100 nM
Compound 3: middle estimate off by 1.2-fold (0.07 log units), on the high side, and the stated range covers the measured number.
By their numbers in this assay, from the lowest: compounds 1, 3 and 2 (each within the scatter of the next).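

In this assay the exchange of 2-chlorophenyl for 4-chlorophenyl on the sulfonamide nitrogen gives a 1.5-fold lower number from compound 2 to compound 3 (0.18 log units; within the scatter) and stays within the usual scatter, so this pair does not separate the two chlorophenyl groups. Chloro in place of methoxy on an aromatic carbon, read with the group otherwise kept as in compound 1, gives a 1.1-fold higher number from compound 1 to compound 3 (0.04 log units; within the scatter) as the second step, so the 4-methoxyphenyl, 2-chlorophenyl and 4-chlorophenyl groups on this nitrogen all lie within the scatter of one another. No supporting measurement is available to explain these small steps.

Still open, going by these compounds, is whether an amine or a carboxylic acid on this aromatic ring, in place of the chloro, would give a step beyond the scatter. The same question stands for a longer chain in place of the ethyl on the sulfonamide nitrogen.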